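This account rests on a few compounds, and the source may have more. Where it says the series, first, only, none or still open, it means among the compounds named here.

Compound 1 `CC(C)n1ncc2c(C(=O)Nc3cccnc3)cccc21` and compound 2 `CC(C)n1ncc2c(C(=O)NCc3cn(-c4ccc(I)cc4)nn3)cccc21` share the same core and amide linkage and differ only in what hangs on the amide nitrogen. In a functional assay on MCF7 cells (Homo sapiens) for inhibition, read by MTT assay, with a stated time of 72 h (on this read-out higher numbers stand for weaker inhibition and lower numbers for stronger inhibition), compound 1 gives > 40000 nM, which is a limit of the assay and not a number. In this assay compound 2 gives > 40000 nM, likewise a limit of the assay rather than a number. Among the compounds with values here, compound 2 thus stands at the limit of > 40000 nM in this assay, at which 2 of the 2 values shown sit; no order between compound 1 and compound 2 can be read from these values, and no step between measured compounds is available. Compound 3 `Cc1ccccc1-n1cc(CNC(=O)c2cccc3c2cnn3C(C)C)nn1` is the next member, differing from compound 2 in one place: 2-methylphenyl in place of 4-iodophenyl on an aromatic nitrogen. With nothing measured for a change of this kind, the expectation for compound 3 rests only on where compound 2 sits, so the step from compound 2 to compound 3 in this assay is expected to be a step that the limit leaves unreadable from compound 2 to compound 3, none beyond the scatter, most likely ending again at a limit. Compound 3 is accordingly estimated at 60000 nM in this assay, with a range from 20000 nM to 200000 nM, and the chance of a numeric result is judged small.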

Compound 3, half-maximal inhibitory concentration: > 40000 nM
Compound 3 was reported as a limit (the forecaster's own chance of this, stated with the estimate: 85%); the middle value lies beyond the limit too.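

No step can be read from compound 2 to compound 3 in this assay, and the values give no order between them; all remain at one limit of the assay: the limit of > 40000 nM in this assay, at which 3 of the 3 values shown sit.

The compounds shown leave open whether any group on the amide nitrogen or on the aromatic nitrogen gives a numeric value in this assay.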